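Removing a Bromo Group from a Weak Cytotoxic Compound

The compounds below may be only part of what the source reports. "The series", "measured", "known", "first", "only" and "open" are said of these compounds alone.

Compound 2 `Cc1ccc2nc(/N=C3\C(=O)N(CN(C)C)c4cccc(Br)c43)sc2c1` was tested in an ADME assay on MCF-10A cells (Homo sapiens) for cytotoxicity, read by sulforhodamine B assay, with a stated time of 48 h (a higher number here means a weaker inhibitor of growth, a lower number a stronger inhibitor of growth), and gave 21800 nM. That is the highest of the two numbers gathered so far, but its neighbour compound 1 `CCN(CC)CN1C(=O)/C(=N\c2nc3ccc(C)cc3s2)c2ccccc21` sits close: in this assay compound 1 gives 20400 nM, and the gap between the two lies within the usual scatter, so the two cannot be told apart. The next compound, compound 3 `Cc1ccc2nc(/N=C3\C(=O)N(CN(C)C)c4ccccc43)sc2c1`, differs from compound 2 in one place: hydrogen in place of bromo on an aromatic carbon, a hydrogen in place of bromo on an aromatic carbon. Within the data shown here, no measured pair shows how this kind of change plays out here, so the expectation rests only on the two numbers already in hand, which sit close together. The expected step is small, a 1.0-fold lower number from compound 2 to compound 3 (0.02 log units; within the scatter), with no direction beyond the scatter. Compound 3 is therefore estimated at 21000 nM, within a range from 8000 nM to 50000 nM.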

Compound 3, concentration for 50% growth inhibition: 13400 nM
For compound 3 the middle estimate is 1.6-fold (0.20 log units) above the measured one, and the stated range covers the measured number.
By their numbers in this assay, from the lowest: compounds 3, 1 and 2 (each within the scatter of the next).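

Replacing bromo with hydrogen on an aromatic carbon gives the first direct reading at this position: in this assay the change gives a 1.6-fold lower number from compound 2 to compound 3 (0.21 log units; within the scatter), so the bromo is not shown to matter for growth inhibition in these cells. The second one-place comparison, dimethylamino in place of diethylamino on the saturated chain carbon bound to the amide-type nitrogen, gives a 1.5-fold lower number from compound 1 to compound 3 (0.18 log units; within the scatter), so this change cannot be told apart from repeat variation either. Neither change moves the number beyond the scatter.

Going by these compounds, whether a methoxy group or a carboxylic acid on that aromatic carbon, or a morpholine in place of dimethylamino, would do so remains open. Nothing shown here offers an explanation for these numbers.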